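The source may hold more compounds than are shown below. What is called first, only, known or untested is meant among the compounds shown, and "the series" means these compounds.

Measured compounds in an assay for inhibition of Tryptophan 2,3-dioxygenase (Homo sapiens), with stated times of 10 min and 60 min, tested at 100 uM; a lower number here means a weaker effect, a higher number a stronger effect of the compound at the concentration tested:
compound 1 `CC(C)n1ncc2c(NCc3ccccc3[N+](=O)[O-])cc(C(F)(F)F)cc21` gives 32%
compound 2 `O=[N+]([O-])c1cccc(CNc2cc(C(F)(F)F)cc3[nH]ncc23)c1` gives 82%
compound 3 `CS(=O)(=O)c1ccc(CNc2cc(C(F)(F)F)cc3[nH]ncc23)c([N+](=O)O)c1` gives 98%

Among the three numbers, compound 2 stands second highest. The nearest number belongs to compound 3, higher and beyond the scatter; the furthest belongs to compound 1, lower and likewise beyond the scatter. All three compounds carry a nitro group on the benzylic ring; compound 3 additionally carries a methylsulfonyl group, while compound 1 alone bears an isopropyl group on the shared core. For the measured compounds named here, no pair among them differs in a single place, so no step can be attributed to one change.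

The next compound, compound 4 `OC1CCCC(Nc2cccc(CNc3cc(C(F)(F)F)cc4[nH]ncc34)c2)C1`, differs from compound 2 as follows: (3-hydroxycyclohexyl)amino in place of nitro on an aromatic carbon. The change sits on an aromatic carbon of a six-membered aromatic ring of carbon only, meta to a large group.

Going by the values given here, no measured pair informs a step of this kind. Both compounds that read high in this assay keep the nitro group, and nothing here shows what its loss does. A downward step beyond the scatter is expected, but with wide uncertainty. For compound 4 the estimate is 62% with a range of 30% to 92%, meaning an expected step of a number 20 percentage points lower from compound 2 to compound 4 (beyond the scatter).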

Compound 4, a percentage reported as inhibition, at one concentration (the size of the read-out at that concentration, not a potency): 23%
Compound 4: the middle estimate sits 39 percentage points above what was measured; the measured number lies below the stated range.
By their numbers in this assay, from the lowest: compounds 4 and 1 (each within the scatter of the next); then compound 2; then compound 3.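

In this assay, for the compounds shown here, placing (3-hydroxycyclohexyl)amino instead of nitro on this aromatic carbon, meta to a large group, gives a number 59 percentage points lower from compound 2 to compound 4 (beyond the scatter) as the first step that can be read at a single place. The read-out at the tested concentration therefore depends strongly on what occupies this position, and this exchange is not tolerated without a large loss. The step combines the departure of nitro with the arrival of a six-membered non-aromatic ring, an amine linkage and a hydroxyl group, and no measurement bears on why the read-out falls.

Going by these compounds, what remains open is whether the step follows from losing nitro or from the size and makeup of the incoming group, which a plain amino group or a cyclohexylamino group without the hydroxyl on the same carbon would help to separate. Whether a small group such as nitrile or a carboxylic acid at this position could retain the read-out of compound 2 also stays unresolved.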